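Cytotoxicity of a thioether analogue on MT2 cells

The source may report more compounds than this note shows. Statements on the series, on what has been measured and on what is new or still open speak of the compounds shown alone.

Compound 1 `Cc1nc(C)c([C@H](OC(C)(C)C)C(=O)O)c(N2CCC(C)(C)CC2)c1-c1ccc(OCCc2ccc(C#N)cc2)cc1`: >= 33500 nM
Compound 2 `Cc1nc(C)c([C@H](OC(C)(C)C)C(=O)O)c(N2CCC(C)(C)CC2)c1-c1ccc(OCCc2ccc(F)cc2F)cc1`: >= 33500 nM
Compound 3 `Cc1nc(C)c([C@H](OC(C)(C)C)C(=O)O)c(N2CCC(C)(C)CC2)c1-c1ccc(CCCc2ccc(F)cc2)cc1`: >= 32000 nM

In a toxicity assay on MT2 cells (Homo sapiens) for cytotoxicity, read by XTT assay, with a stated time of 4 days (on this read-out higher numbers stand for lower toxicity in this test and lower numbers for higher toxicity in this test), compound 1 gives >= 33500 nM, which is a limit of the assay and not a number. Compound 2 likewise reports only a limit, >= 33500 nM. Compound 3 also sits at a limit, >= 32000 nM. Compound 1 therefore stands at the limit of >= 33500 nM in this assay, at which 2 of the 3 values shown sit, shared with compound 2, while compound 3 stands at the limit of >= 32000 nM in this assay, at which 1 of the 3 values shown sits. Within the data shown here, none of the measured steps can be read: a step that the two limits leave unreadable from compound 1 to compound 2, a step that the two limits leave unreadable from compound 1 to compound 3 and a step that the two limits leave unreadable from compound 2 to compound 3 all run between limits.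

Compound 4 `Cc1nc(C)c([C@H](OC(C)(C)C)C(=O)O)c(N2CCC(C)(C)CC2)c1-c1ccc(SCCc2ccc(F)cc2)cc1` differs from compound 1 by (2-(4-fluorophenyl)ethyl)sulfanyl in place of 2-(4-cyanophenyl)ethoxy on an aromatic carbon. Among the measured compounds shown here, the steps that bear on it, from compound 1 to compound 2 and from compound 1 to compound 3, both show that exchanging the aryl group and its linker left the read-out at the assay limit, so no step beyond the scatter is expected in this assay. Compound 4 is estimated at 33500 nM (range 15000 nM to 70000 nM), meaning an expected step of a number no higher from compound 1 to compound 4 (the limit leaves the size open), most likely again reported only as a limit.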

Compound 4, half-maximal cytotoxic concentration: >= 32000 nM
Compound 4 ended at the assay's limit (the forecaster's own chance of this, stated with the estimate: 85%); the middle value does not contradict the limit.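

In this assay compound 4 gives >= 32000 nM, which is a limit of the assay and not a number. The steps from compound 4 to compound 1, compound 2 and compound 3 all run between limits and cannot be read. The compounds shown leave open whether the exchanged groups change the read-out at all.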